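This account rests on a few compounds, and the source may have more. Where it says the series, first, only, none or still open, it means among the compounds named here.

Measured so far:
- compound 1 `CC(C)CN(CC(=O)NN(Cc1ccccc1)c1cnccn1)NC(=O)CBr` gives 24100 nM
- compound 2 `CC(C)CN(CC(=O)NN(Cc1ccccc1)c1cnccn1)NC(=O)Cc1cccc(Br)c1` gives 45000 nM
- compound 3 `CC(C)CN(CC(=O)N(Cc1ccccc1)NC(=O)OCc1ccccc1)/N=C/c1cccc(B(O)O)c1` gives 16900 nM

All three values come from a functional assay on L1210 cells (Mus musculus) for inhibition; a lower number here means a stronger inhibitor, a higher number a weaker inhibitor. Compound 2, at 45000 nM, has the highest of the three numbers. Compound 1 lies within the scatter of it, whereas compound 3 has a lower number, beyond the scatter.

The next compound is compound 4 `CC(C)CN(CC(=O)NN(Cc1ccccc1)c1cnccn1)/N=C/c1cccc(B(O)O)c1`, not yet measured. The change from compound 2 is a group of 11 heavy atoms (7 carbon, 1 boron, 1 nitrogen, 2 oxygen; one six-membered aromatic ring of carbon only) in place of a group of 11 heavy atoms (8 carbon, 1 nitrogen, 1 oxygen, 1 bromine; one six-membered aromatic ring of carbon only), on an amine nitrogen.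

Among the compounds with values here, the only measured step is a 1.9-fold higher number from compound 1 to compound 2 (0.27 log units; within the scatter). It alters the group that leaves here, and replacing bromo with 3-bromophenyl on that group left the number within the scatter. That is slim evidence, but it gives no sign that this group is sensitive to change. Within the data shown here, compound 3, at 16900 nM, is the only measured compound carrying the entering group, although the rest of its structure differs from compound 4. Its value suggests that the entering group is compatible with a number in the same general range, perhaps somewhat lower than that of compound 2.

A small move toward a lower number is therefore expected, estimated as a 1.9-fold lower number from compound 2 to compound 4 (0.27 log units; within the scatter). Among the measured compounds shown here, with only three measured compounds, the range is kept wide. For compound 4 the estimated value is 24000 nM, with an expected range from 10000 nM to 55000 nM.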

Compound 4, half-maximal inhibitory concentration: > 80000 nM
Compound 4: no number, only a limit; the forecaster's own chance of this, stated with the estimate: 5%; middle value at least 3.3-fold (0.52 log units) from the limit.
By their numbers in this assay, from the lowest: compounds 3, 1 and 2 (each within the scatter of the next, the first and the last beyond it). At a limit, above all of these: compound 4.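

In this assay the reading for compound 4 is a limit and not a number: the limit of > 80000 nM in this assay, at which 1 of the 4 values shown sits.

Within the data shown here, the group on the amine nitrogen now shows a change beyond the scatter, with an at least 3.3-fold higher number from compound 1 to compound 4 (0.52 log units; beyond the scatter), whereas the only earlier step at this position, a 1.9-fold higher number from compound 1 to compound 2 (0.27 log units; within the scatter), gave no such sign. Against compound 2 the picture is less firm, with an at least 1.7-fold higher number from compound 2 to compound 4 (0.24 log units; that floor lies within the scatter); the floor of this step does not by itself separate the boron-containing group from the bromine-containing one, and its true size remains unknown.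

The compounds shown leave open which part of the entering group goes with the loss, the boronic acid or the carbon-nitrogen double bond, since the two arrive together in this change. A carboxylic acid in place of the boronic acid on the same ring, or a saturated amine link in place of the double bond, would separate these two parts, and a compound reading below the limit would give the step a real size.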